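The compounds below may be only part of what the source reports. "The series", "measured", "known", "first", "only" and "open" are said of these compounds alone.

Three compounds share one core and differ only in what sits on a saturated chain carbon bound to an aromatic carbon. Compound 1 `CCNC(=O)c1noc(-c2cc(C(C)C)c(O)cc2O)c1-c1cc(COCC(N)=O)no1` carries a carbamoylmethoxy group at that place; in a functional assay on A2780 cells (Homo sapiens) for inhibition (on this read-out lower numbers stand for stronger inhibition and higher numbers for weaker inhibition), compound 1 gives "not determined" (no result reported). Compound 3 `CCNC(=O)c1noc(-c2cc(C(C)C)c(O)cc2O)c1-c1cc(CNCCO)no1` is in the same position, with no result: in this assay compound 3 gives "not determined" (no result reported). Only compound 2 `C=CNCc1cc(-c2c(C(=O)NCC)noc2-c2cc(C(C)C)c(O)cc2O)on1` has a number, and in this assay compound 2 gives 43 nM. So compound 1 stands nowhere on the numbers: there is no value to place it against the one measured compound.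

Going by the values given here, compound 4 `CCNC(=O)c1noc(-c2cc(C(C)C)c(O)cc2O)c1-c1cc(CN2CCCC2)no1` is the next step from compound 1, a swap of one group for another of the same heavy-atom count. pyrrolidin-1-yl in place of carbamoylmethoxy on a saturated chain carbon bound to an aromatic carbon No step between measured compounds exists, and compound 1 itself has no number, so neither the size nor the direction of this change can be read from the data; the only anchor is the value of compound 2 in this assay, 43 nM, which is expected to be a fair guide for the shared core. On that basis compound 4 is estimated at about 50 nM, with an expected range from 15 nM to 200 nM.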

Compound 4, half-maximal inhibitory concentration: 55 nM
Estimate against measurement, compound 4: 1.1-fold (0.04 log units) below; measured number inside the range.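

In this assay, placing pyrrolidin-1-yl where compound 2 carries vinylamino gives a 1.3-fold higher number from compound 2 to compound 4 (0.11 log units; within the scatter), so the two compounds cannot be told apart. On a saturated chain carbon bound to an aromatic carbon, then, an open vinylamino group and a five-membered non-aromatic ring give matching results, although this rests on just this one pair. Compound 1 has no single number, so its step to compound 4 cannot be read, and no supporting data speak to why compound 2 and compound 4 match.

On these data alone, whether a larger cyclic amine, such as piperidin-1-yl or morpholin-4-yl, would match these two compounds remains open. So does the outcome for a longer chain ending in a carboxylic acid at this place.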